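The source may hold more compounds than are shown below. What is called first, only, known or untested is meant among the compounds shown, and "the series" means these compounds.

Measured so far in an assay on isolated protein for inhibition of alkaline phosphatase, tissue-nonspecific isozyme (Homo sapiens); on this read-out lower numbers stand for stronger inhibition and higher numbers for weaker inhibition: compound 1 `COc1ccc(OC)c(S(=O)(=O)Nc2cncc(-c3ccncc3)c2)c1` gives 73 nM; compound 2 `COc1ccc(Cl)cc1S(=O)(=O)Nc1cncc(-c2ccncc2)c1` gives 73 nM; compound 3 `COc1ccc(S(=O)(=O)Nc2cccnc2)c(OC)c1` gives 10300 nM.

Compound 2 stands level with compound 1, the two together giving the lowest numbers of the three, while compound 3 gives a far higher number. Compound 4 `COc1ccc(Cl)cc1S(=O)(=O)Nc1cncc(C(=O)N2CCN(C)CC2)c1` carries (4-methylpiperazin-1-yl)carbonyl in place of pyridin-4-yl on an aromatic carbon. Among the measured compounds shown here, the one measured step, no change at the digits printed from compound 1 to compound 2 (within the scatter), concerns a different part of the molecule and says nothing about this replacement. For the measured compounds named here, compound 3, which lacks the pyridin-4-yl among other differences, gives 10300 nM, so a loss is plausible, though no single step supports it. The expected step is a 14-fold higher number from compound 2 to compound 4 (1.14 log units; beyond the scatter), a weakening. Compound 4 is therefore estimated at 1000 nM, with a range from 200 nM to 6000 nM.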

Compound 4, half-maximal inhibitory concentration: 671 nM
Compound 4: the middle estimate sits 1.5-fold (0.17 log units) above what was measured; measured number inside the range.
By their numbers in this assay, from the lowest: compounds 1 and 2 (each within the scatter of the next); then compound 4; then compound 3.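

At this position on the ring carrying the sulfonamide, two atoms from the ring nitrogen, (4-methylpiperazin-1-yl)carbonyl in place of pyridin-4-yl gives a 9.2-fold higher number from compound 2 to compound 4 (0.96 log units; beyond the scatter) in this assay. Among the compounds shown here, this is the first change confined to this place, and it shows that the read-out responds to the group here, while a non-aromatic ring joined through a carbonyl still leaves measurable inhibition. No available evidence explains this result. From the compounds shown here alone, it remains open whether the carbonyl or the loss of the aromatic ring matters more. A phenyl group or a simple dimethylamino carbonyl at this place could separate the two.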